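A few compounds are considered here, and "the series" means these few. Any claim that something is new, unique, unknown or untested is made for them only; others in the source may bear on it.

In an ADME assay on a cell-free system (plasma, Mus musculus) for metabolic stability, read by LC-MS, tested at 2 uM (on this read-out lower numbers stand for a shorter-lived compound and higher numbers for a longer-lived compound), compound 1 `CCCCCNC(=O)n1cc(-c2ccccc2)oc1=O` gives > 2 h, which is a limit of the assay and not a number. Compound 2 `CCOCCNC(=O)n1cc(-c2ccccc2)oc1=O` gives 1.33 h and compound 3 `O=C(NCCCCc1ccccc1)n1cc(-c2ccc(F)cc2)oc1=O` gives 1.5 h, two values within the scatter of each other. Compound 4 `COc1cc(-c2cn(C(=O)NCCCCc3ccccc3)c(=O)o2)ccc1F` differs from compound 3 by methoxy in place of hydrogen on an aromatic carbon, turning 4-fluorophenyl into 4-fluoro-3-methoxyphenyl. Among the measured compounds shown here, the only measured step is an at least 1.5-fold lower number from compound 1 to compound 2 (0.17 log units; that floor lies within the scatter). It lies on the chain and not on the aromatic ring, so it bears on this change only weakly. For the measured compounds named here, no measured step covers methoxy on an aromatic carbon, and no shift beyond the scatter is expected in this assay. The estimated change is a 1.1-fold lower number from compound 3 to compound 4 (0.03 log units; within the scatter). Compound 4 is expected at 1.4 h, with an estimated range of 0.7 h to 2.6 h.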

Compound 4, half-life: > 2 h
Compound 4 ended at the assay's limit (the forecaster's own chance of this, stated with the estimate: 25%); middle value at least 1.4-fold (0.15 log units) away from the limit.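

Compound 4 gives > 2 h in this assay, which is a limit of the assay and not a number. Methoxy on this aromatic carbon, ortho to a fluoro group, gives an at least 1.3-fold higher number from compound 3 to compound 4 (0.12 log units; that floor lies within the scatter). This is the first change on the aromatic ring among the compounds shown, and it brings no sign of a shorter-lived compound, though its true size stays unread at the ceiling: the limit of > 2 h in this assay, at which 2 of the 4 values shown sit.

Going by these compounds, how far compound 4 lies past that limit remains open. So does whether a hydroxyl or a chloro group on this same carbon would read like methoxy.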